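This account rests on a few compounds, and the source may have more. Where it says the series, first, only, none or still open, it means among the compounds named here.

The measured compounds:
compound 1, `CCN(c1nc(C)nc2c1nnn2-c1ccc(C(C)C)cc1Br)C(COC)COC`: in an in vitro assay on 293-EBNA cells for binding affinity to corticotropin-releasing factor receptor 1 (Homo sapiens) (on this read-out higher numbers stand for weaker inhibition and lower numbers for stronger inhibition), compound 1 gives 123 nM
compound 2, `CCCCc1nc2c(N(CC)CCCC)nc(C)nc2n1-c1c(Cl)cc(OC)cc1OC`: in this assay compound 2 gives 22 nM

Among the compounds with values here, of these two, compound 1 stands at the higher number, and the gap to compound 2 lies beyond the usual scatter; no step between them is worked out here, as they differ in more than one place.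

Compound 3, `CCOCC(COCC)Oc1nc(C)nc2c1nnn2-c1ccc(C(C)C)cc1Br`, has not been measured. It differs from compound 1 in one place: a group of 10 heavy atoms (7 carbon, 3 oxygen; no ring) in place of a group of 10 heavy atoms (7 carbon, 1 nitrogen, 2 oxygen; no ring), on an aromatic carbon. Within the data shown here, nothing among the measured compounds shows what such an exchange does in this assay, so the expectation rests on the change alone. The step of a 2.4-fold higher number from compound 1 to compound 3 (0.39 log units; beyond the scatter) is expected to lead to a somewhat higher number, a step modest in size but probably beyond the scatter. Compound 3 is accordingly estimated at 300 nM, with a likely range from 100 nM to 1000 nM.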

Compound 3, inhibition constant: 39.7 nM
Beside the measured number, compound 3's estimate is 7.6-fold (0.88 log units) above it, outside the stated range (below it).
By their numbers in this assay, from the lowest: compounds 2 and 3 (each within the scatter of the next); then compound 1.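

On an aromatic carbon of the six-membered aromatic ring, the group of 10 heavy atoms (7 carbon, 3 oxygen; no ring) in place of the group of 10 heavy atoms (7 carbon, 1 nitrogen, 2 oxygen; no ring) gives a 3.1-fold lower number from compound 1 to compound 3 (0.49 log units; beyond the scatter) in this assay, so this position responds to the exchange and the nitrogen-bearing group is not needed there. The step arises although both groups have 0 hydrogen-bond donors, 3 hydrogen-bond acceptors and no net charge. Nothing shown here accounts for the direction or size of this step.

The compounds shown leave open whether a thioether or a simple secondary amine at this position would follow compound 3 or compound 1. They also leave open whether the same exchange would move the number on the core of compound 2.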